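A Methyl on the Urea Nitrogen of a Small Aziridine

The source may hold more compounds than are shown below. What is called first, only, known or untested is meant among the compounds shown, and "the series" means these compounds.

Compound 1 `N#CC1CN1C(N)=O` is a three-membered ring carrying a nitrile and a primary urea. In a functional assay on A-375 cells (Homo sapiens) for inhibition (a higher number here means a weaker inhibitor, a lower number a stronger inhibitor), compound 1 returns only the limit of the measurement, > 90000 nM, which is not a number but the edge of what the assay reports (the limit of > 90000 nM in this assay, at which 1 of the 2 values shown sits). For the measured compounds named here, its larger relative compound 2 `N#CC1CN1C(=O)Nc1cccnc1` is the one compound with an actual number: in this assay compound 2 gives 12000 nM. Going by the values given here, no step between two measured compounds that differ in a single place is available here.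

Compound 3 `CNC(=O)N1CC1C#N` differs from compound 1 by methyl in place of hydrogen on an amide-type nitrogen, or amino to methylamino read one bond further out. Among the compounds with values here, with no measured step of this kind to lean on, the expectation is modest: a small gain at best, quite possibly none beyond the scatter. Compound 3 is therefore expected to stay weak in this assay, with a step of an at least 1.1-fold lower number from compound 1 to compound 3 (0.05 log units; that floor lies within the scatter) and an estimated value of 80000 nM, in a range from 20000 nM to 300000 nM, and it may well again return only a limit.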

Compound 3, half-maximal inhibitory concentration: 17000 nM
Estimate against measurement, compound 3: 4.7-fold (0.67 log units) above; the whole stated range lies above it.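

In this assay, methyl in place of hydrogen on an amide-type nitrogen gives an at least 5.2-fold lower number from compound 1 to compound 3 (0.72 log units; beyond the scatter). For the compounds shown here, this is the first step that can be read, and it shows that a single added carbon at this nitrogen is enough to move the read-out beyond the scatter. For compound 1 the value of > 90000 nM is a limit of the assay and not a number. The step is therefore a floor, and its true size stays unfixed because it starts from a limit: the limit of > 90000 nM in this assay, at which 1 of the 3 values shown sits.

The compounds shown leave open whether the effect belongs to methyl alone or whether it would continue with a longer chain on the same nitrogen, such as ethyl or propyl, or with a second methyl there. With one step in one assay, they also leave open whether the same change would give a comparable step on a different urea substituent, so no wider pattern can be drawn from this pair.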